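The source may report more compounds than this note shows. Statements on the series, on what has been measured and on what is new or still open speak of the compounds shown alone.

Measured compounds and their values:

- Compound 1, `Cc1cccc(C#Cc2ccc3c(n2)CCN(C)C3=O)c1`: 820 nM
- Compound 2, `Cc1cccc(C#Cc2ccc3c(n2)CCN(C(C)C)C3=O)c1`: 510 nM
- Compound 3, `Cc1cccc(C#Cc2ccc3c(n2)CCN(C2CCCCC2)C3=O)c1`: 3210 nM

All three compounds were tested in an assay on HEK293 cells for displacement of a labelled ligand from metabotropic glutamate receptor 5 (Homo sapiens), with a stated time of 2 h; a lower number here means a stronger inhibitor, a higher number a weaker inhibitor. They share one core and differ only in the group on the amide-type nitrogen in the ring. Compound 3, which carries a cyclohexyl there, gives the highest number of the three: the step of a 3.9-fold higher number from compound 1 to compound 3 (0.59 log units; beyond the scatter) and the step of a 6.3-fold higher number from compound 2 to compound 3 (0.80 log units; beyond the scatter) both lie beyond the scatter, whereas the step of a 1.6-fold lower number from compound 1 to compound 2 (0.21 log units; within the scatter) does not.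

Compound 4, `O=C1c2ccc(C#Cc3cccs3)nc2CCN1C1CCCCC1`, keeps the cyclohexyl of compound 3 and changes a different part of the molecule: thiophen-2-yl in place of 3-methylphenyl on a triple-bonded carbon. For the measured compounds named here, none of the measured steps touches this position; every step so far concerns the group on the nitrogen. There is therefore no direct guide to the size or direction of the change in this assay. Going by the values given here, with no step to lean on, the expectation for compound 4 is a number close to that of compound 3, with a wide range on either side, which means an expected step of a 1.2-fold higher number from compound 3 to compound 4 (0.10 log units; within the scatter). The estimate for compound 4 in this assay is 4000 nM, with a range from 1300 nM to 12000 nM.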

Compound 4, inhibition constant: 720 nM
Beside the measured number, compound 4's estimate is 5.6-fold (0.74 log units) above it; measured number outside the range, below it.
By their numbers in this assay, from the lowest: compounds 2, 4 and 1 (each within the scatter of the next); then compound 3.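

In this assay, for the compounds shown here, putting thiophen-2-yl in place of 3-methylphenyl on the triple-bonded carbon gives a 4.5-fold lower number from compound 3 to compound 4 (0.65 log units; beyond the scatter) and shows that the number responds to this position as well as to the group on the nitrogen, the only place changed in the earlier steps. The change replaces a six-membered aromatic ring of carbon only with a five-membered aromatic ring holding one sulfur, and it also alters the heavy-atom count and adds a hydrogen-bond acceptor, so this single step cannot show which of these differences matters. No measurement available here explains the shift.

Still open, from the compounds shown here alone, is whether furan-2-yl or pyridin-2-yl on the triple-bonded carbon would move the number in the same direction, a comparison that could help separate the effect of ring size from that of the particular hetero atom. It is also unknown whether thiophen-2-yl would give a similar step with methyl or isopropyl on the nitrogen, since this one comparison has cyclohexyl there.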